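Amino for hydroxy on the shared core

A few compounds are considered here, and "the series" means these few. Any claim that something is new, unique, unknown or untested is made for them only; others in the source may bear on it.

- compound 1 `O=C(O)c1csc(-n2nc(-c3ccccc3)c3cccnc32)n1` gives 65 mL/min/kg
- compound 2 `O=C(O)c1csc(-n2nc(-c3ccccc3)c3ccc(O)cc32)n1` gives 522 mL/min/kg

In an ADME assay (liver) for metabolic stability, with Liver microsome (Rattus norvegicus) as the target, using microsomes (on this read-out higher numbers stand for fast clearance and lower numbers for slow clearance), compound 2 stands highest of the two measured compounds, and the gap down to compound 1 lies beyond the scatter. The two differ in more than one place, so their values show only that gap and isolate no single change.

Compound 3 `Nc1ccc2c(-c3ccccc3)nn(-c3nc(C(=O)O)cs3)c2c1` differs from compound 2 by one change amino in place of hydroxy on an aromatic carbon on the shared core: amino in place of hydroxy on an aromatic carbon. For the measured compounds named here, no measured pair shows this change, so its size remains a judgement. With compound 2 at 522 mL/min/kg as the higher of the two numbers, a downward move of moderate size is expected, beyond the scatter but not by a wide margin. A step of a 2.4-fold lower number from compound 2 to compound 3 (0.38 log units; beyond the scatter) is expected in this assay on that reading. Compound 3 is estimated at 220 mL/min/kg with an expected range from 70 mL/min/kg to 600 mL/min/kg in this read-out.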

Compound 3, clearance: 208 mL/min/kg
For compound 3 the middle estimate is 1.1-fold (0.02 log units) above the measured one, within the range that was stated.
By their numbers in this assay, from the lowest: compound 1; then compound 3; then compound 2.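

For the compounds shown here, the pair gives the first reading of a single change on the shared core in this assay: amino in place of hydroxy on an aromatic carbon goes with a 2.5-fold lower number from compound 2 to compound 3 (0.40 log units; beyond the scatter). The number at this position, meta to a fused ring and para to a fused ring, therefore responds to the exchange of one heavy atom. The two groups carry the same counts of hydrogen-bond donors and acceptors and no net charge, so those counts alone do not set the value, and nothing shown bears on why the number moves.

Still open, going by these compounds, is whether the step is specific to amino or would also follow other replacements of hydroxy here, such as a methoxy group or a fluorine. On these data alone, it is also open whether the same exchange gives a similar step with the carboxylic acid replaced by an amide.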